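The source may report more compounds than this note shows. Statements on the series, on what has been measured and on what is new or still open speak of the compounds shown alone.

Compound 1 `C[C@@H](C(=O)O)c1nn(Cc2cn3cc(OCC4CC4)c(Cl)cc3n2)c2ccccc2c1=O` — 3180 nM
Compound 2 `O=C(O)Cn1nc(Cc2cn3cc(OCC4CC4)c(Cl)cc3n2)c2ccccc2c1=O` — 275 nM
Compound 3 `C[C@H](C(=O)O)n1nc(Cn2cc3cc(OCC4CC4)c(Cl)cc3n2)c2ccccc2c1=O` — 197 nM

These three compounds were tested in a functional assay on HFL1 cells for antagonist activity at sphingosine 1-phosphate receptor 2 (Homo sapiens), read by ELISA, with a stated time of 24 h, in the presence of a further agent that is not named here; on this read-out lower numbers stand for stronger inhibition and higher numbers for weaker inhibition. Compound 1 gives the highest number of the three, so it is the weakest inhibitor in this set. Compound 2, which carries an unbranched acetic acid instead of the methyl-bearing propanoic acid of compound 1, gives a lower number, a gap well beyond the scatter, and compound 3, whose acid-bearing carbon is drawn S and sits on a differently arranged core, gives the lowest number, a gap beyond the scatter as well.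

Compound 4 `C[C@H](C(=O)O)c1nn(Cc2cn3cc(OCC4CC4)c(Cl)cc3n2)c2ccccc2c1=O` has not yet been measured. It differs from compound 1 only in configuration: the two compounds have the same atoms and bonds and differ only in configuration as drawn: 1 of 1 stereo elements differ; a stereocentre at a saturated chain carbon is drawn R in compound 1 and S in compound 4. Mirror-image pairs of this kind often differ markedly in this assay, and compound 1 is the poorest compound shown while compound 3, drawn S at the corresponding carbon, gives 197 nM. A step downward, beyond the scatter, is therefore expected from compound 1 to compound 4, of size an 8.0-fold lower number from compound 1 to compound 4 (0.90 log units; beyond the scatter). Compound 4 is expected to give about 400 nM, with a plausible range from 100 nM to 1600 nM.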

Compound 4, half-maximal inhibitory concentration: 19 nM
Compound 4: middle estimate off by 21-fold (1.32 log units), on the high side; the measured number lies below the stated range.
By their numbers in this assay, from the lowest: compound 4; then compounds 3 and 2 (each within the scatter of the next); then compound 1.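

In this assay, turning the stereocentre at the saturated chain carbon from R to S gives a 170-fold lower number from compound 1 to compound 4 (2.22 log units; beyond the scatter), a large step. The earlier compounds shown here could not show this, as no two of them differed in just one place, and the poor number of compound 1 might otherwise have been read as a verdict on its acid-bearing side chain or its core; compound 4 carries that same side chain and core, so the verdict applies to the R configuration only. The whole gap can be assigned to this single stereocentre because nothing else separates the pair: the fact that compounds 1 and 4 differ only in the configuration as drawn

From the compounds shown here alone, it remains open whether the methyl group on the stereocentre helps or hurts in its own right, something that the unbranched acetic acid on the core of compound 4 would reveal, and whether the S preference extends to other cores. Also open, going by these compounds, is how far this carbon tolerates change, for instance an ethyl group in place of the methyl, or an amide or tetrazole in place of the carboxylic acid.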